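The source may hold more compounds than are shown below. What is called first, only, known or untested is meant among the compounds shown, and "the series" means these compounds.

- Compound 1 `CS(=O)(=O)Nc1ccc2c(c1)S(=O)(=O)N=C(c1c(O)c(-c3cccs3)nn(CC3(C(F)(F)F)CC3)c1=O)N2`: > 1 h
- Compound 2 `CS(=O)(=O)Nc1ccc2c(c1)S(=O)(=O)N=C(c1c(O)c(-c3cccs3)nn(CC3(C(F)(F)F)CCC3)c1=O)N2`: 1 h
- Compound 3 `CS(=O)(=O)Nc1ccc2c(c1)S(=O)(=O)N=C(c1c(O)c(-c3cccs3)nn(CCC3CCC3)c1=O)N2`: > 1 h

These three compounds share one core and were tested in an in vitro ADME assay on microsomes from liver (Homo sapiens) for metabolic stability, tested at 5 uM; a higher number here means that the compound lasts longer, a lower number that the compound disappears faster. Compound 3 has no exact number in this assay, as its > 1 h is a limit. Compound 1 also reports only a limit, > 1 h. Compound 2 gives a number, 1 h. The set therefore gathers at the limit of > 1 h in this assay, at which 2 of the 3 values shown sit.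

Compound 4 `CS(=O)(=O)Nc1ccc2c(c1)S(=O)(=O)N=C(c1c(O)c(-c3cccs3)nn(CCC3CCCC3)c1=O)N2` differs from compound 3 by cyclopentyl in place of cyclobutyl on a saturated chain carbon, two bonds along the chain from an aromatic nitrogen. Going by the values given here, no measured step makes this exact change. The closest is a number no higher from compound 1 to compound 2 (the limit leaves the size open), where a ring also grows by one carbon, but on a group bearing trifluoromethyl. The other two, a step that the two limits leave unreadable from compound 1 to compound 3 and a number no lower from compound 2 to compound 3 (the limit leaves the size open), exchange those groups for cyclobutylmethyl. None of the three has a readable size, so none supplies a magnitude to carry over.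

With no evidence for a real shift, no step beyond the scatter is expected, and compound 4 may well be reported only as a limit. The expected change is a number no higher from compound 3 to compound 4 (the limit leaves the size open). For compound 4 the estimated half-life is 1 h, with an expected range from 0.6 h to 1.5 h.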

Compound 4, half-life: > 1 h
Compound 4: only a limit was reported; the forecaster's own chance of this, stated with the estimate: 60%; the middle value lies on the limit itself.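

In this assay compound 4 also reports only a limit, > 1 h. Cyclopentyl in place of cyclobutyl, on a saturated chain carbon, two bonds along the chain from an aromatic nitrogen, therefore leaves the half-life reported as a limit, just as it was for compound 3. The new data give a number no lower from compound 2 to compound 4 (the limit leaves the size open) and none of the new steps can be read for size. The position thus accepts a ring larger by one carbon with no exact number appearing, and the set gathers further at one reading: the limit of > 1 h in this assay, at which 3 of the 4 values shown sit.

From the compounds shown here alone, whether compound 3 and compound 4 truly differ in how long they last stays open, as does how far either lies beyond the limit. Also open, going by these compounds, is how the half-life in this assay would respond at this place to an amine, a carboxylic acid or a longer chain.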